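Bromo to chloro exchange: cytotoxicity notes on the series

This account rests on a few compounds, and the source may have more. Where it says the series, first, only, none or still open, it means among the compounds named here.

Measured so far in an ADME assay on RAW264.7 cells (Mus musculus) for cytotoxicity, read by MTT assay, with a stated time of 24 h; on this read-out higher numbers stand for lower toxicity in this test and lower numbers for higher toxicity in this test:
- compound 1 `O=C(Nc1ccc(F)cc1F)c1cc(Br)ccc1O`: 13800 nM
- compound 2 `O=C(Nc1ccc(Br)cc1F)c1cc(F)ccc1O`: 7900 nM
- compound 3 `O=C(Nc1ccc(F)cc1F)c1cc(Cl)ccc1O`: 14600 nM

Compounds 1 and 2 share the same atoms joined differently; the difference between the two cores is not broken down here. The step of a 1.1-fold higher number from compound 1 to compound 3 (0.02 log units; within the scatter) is chloro in place of bromo on an aromatic carbon. Compound 4 `O=C(Nc1ccc(Cl)cc1F)c1cc(F)ccc1O` is not yet measured; it carries chloro in place of bromo on an aromatic carbon. This is the same kind of change as from compound 1 to compound 3, but the surroundings differ: in compound 3 the chloro sits meta to a large group and para to a hydroxy group, in compound 4 meta to a fluoro group and para to a large group.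

For compound 4 a step of a 1.1-fold higher number from compound 2 to compound 4 (0.03 log units; within the scatter) is expected in this assay, resting on the flat step a 1.1-fold higher number from compound 1 to compound 3 (0.02 log units; within the scatter). Compound 4 is thus estimated at 8500 nM, expected between 4500 nM and 16000 nM.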

Compound 4, half-maximal cytotoxic concentration: 7700 nM
Beside the measured number, compound 4's estimate is 1.1-fold (0.04 log units) above it; low and high end bracket the measured number.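

In this assay, chloro in place of bromo on an aromatic carbon gives a 1.0-fold lower number from compound 2 to compound 4 (0.01 log units; within the scatter), so the exchange is also flat on the core of compound 2. Set beside the earlier case, the change carries from one core to the other with no gap that can be told from noise: the same change on two cores in this assay, a 1.1-fold higher number (0.02 log units; within the scatter) from compound 1 to compound 3 and a 1.0-fold lower number (0.01 log units; within the scatter) from compound 2 to compound 4, 1.1-fold (0.04 log units) apart, within the scatter of two such steps. This holds only for these two cores and these two surroundings in this assay; it gives no reason for the flatness and does not show that the exchange would stay flat on another core or in another test.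

Still open, on these data alone, is whether a methyl or a nitrile at the same place would leave the number as flat. Also open, as far as these compounds go, is how an amine or a carboxylic acid in place of the hydroxy group would read.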